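Fused Isoquinoline Replaces Methylpyridine on the Ring Nitrogen

This account rests on a few compounds, and the source may have more. Where it says the series, first, only, none or still open, it means among the compounds named here.

Two measured compounds share a core joined through a sulfonyl group to a six-membered ring with two nitrogens, whose far nitrogen carries an aromatic group. Compound 1 `C[C@@H]1CN(c2ccc(C(F)(F)F)cn2)[C@@H](C)CN1S(=O)(=O)C[C@]12CC[C@H](CC1=O)C2(C)C` gives 6310 nM in a functional assay on CHO-K1 cells for antagonist activity at C-X-C chemokine receptor type 3 (Homo sapiens), read by FLIPR and calcium flux; a lower number here means a stronger inhibitor, a higher number a weaker inhibitor. Compound 2 `Cc1ccc(N2CCN(S(=O)(=O)C[C@]34CC[C@H](CC3=O)C4(C)C)CC2)nc1` differs from compound 1 in the substituents on that ring and in the aromatic group. In this assay compound 2 reaches only > 31600 nM, which is a limit of the assay rather than a number (the limit of > 31600 nM in this assay, at which 1 of the 2 values shown sits). Compound 2 therefore stands at the weak end of what is shown, and compound 1 is the only compound with a numeric reading. Going by the values given here, no step between two measured compounds that differ in one place is available.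

Compound 3 `CC1(C)[C@@H]2CC[C@@]1(CS(=O)(=O)N1CCN(c3cc4ccccc4cn3)CC1)C(=O)C2` arises from compound 2 by the change (isoquinolin-3-yl in place of 5-methylpyridin-2-yl on an amine nitrogen in a ring). Among the compounds with values here, with no comparable step to lean on, the direction rests on expectation alone. The estimate for compound 3 is 10000 nM, within a range from 2000 nM to 31600 nM. The expected step, an at least 3.1-fold lower number from compound 2 to compound 3 (0.49 log units; beyond the scatter), points toward stronger inhibition, though a reading that again stops at the limit remains quite possible.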

Compound 3, half-maximal inhibitory concentration: 15800 nM
Beside the measured number, compound 3's estimate is 1.6-fold (0.20 log units) below it, within the range that was stated.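

In this assay, isoquinolin-3-yl in place of 5-methylpyridin-2-yl on the amine nitrogen in the ring gives an at least 2.0-fold lower number from compound 2 to compound 3 (0.30 log units; that floor lies within the scatter). Compound 2 has no numeric reading, only a limit of the assay: the limit of > 31600 nM in this assay, at which 1 of the 3 values shown sits. From the compounds shown here alone, the true size of the step therefore stays unknown and its floor alone does not go beyond the scatter. Even so, compound 3, at 15800 nM, shows that this position can give a numeric reading without the substituents that compound 1 carries on the six-membered non-aromatic ring. The added six-membered aromatic ring of carbon does not push the reading back to the limit.

The compounds shown leave open whether the gain comes with the added aromatic ring itself or with the different placement of the ring nitrogen, which a plain phenyl or a quinolin-2-yl at the same position would help to separate. They also leave open how isoquinolin-3-yl would read on the substituted ring of compound 1, or with a trifluoromethyl group or an amine on it.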